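The compounds below may be only part of what the source reports. "The series", "measured", "known", "first", "only" and "open" are said of these compounds alone.

In a functional assay on DU-145 cells (Homo sapiens) for inhibition, read by trypan blue exclusion, with a stated time of 96 h (on this read-out lower numbers stand for stronger inhibition of growth and higher numbers for weaker inhibition of growth), the measured compounds so far are:
- compound 1 `COc1cc(/C=C(/Sc2ccc(Br)cc2)C(=O)c2ccc(Br)cc2)ccc1F` gives 10000 nM
- compound 2 `O=C(/C(=C/c1ccc(O)c([N+](=O)[O-])c1)SCc1ccc(Br)cc1)c1ccc([N+](=O)[O-])c(Cl)c1` gives 1000 nM

Compound 1 holds the higher of the two numbers, and compound 2 lies lower by more than the scatter.

Compound 3 `COc1ccc(/C=C(/Sc2ccc(Br)cc2)C(=O)c2ccc(Br)cc2)c(F)c1` is not yet measured. It carries 2-fluoro-4-methoxyphenyl in place of 4-fluoro-3-methoxyphenyl on a double-bonded chain carbon bound to a double-bonded chain carbon. Going by the values given here, no measured step sizes this change, so in this assay no step beyond the scatter is expected, in either direction. The estimate is a small move (a 1.7-fold lower number from compound 1 to compound 3 (0.22 log units; within the scatter)). The estimated value for compound 3 is 6000 nM (expected range 1500 nM to 20000 nM).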

Compound 3, concentration for 50% growth inhibition: 20000 nM
For compound 3 the middle estimate is 3.3-fold (0.52 log units) below the measured one, and the stated range covers the measured number.
By their numbers in this assay, from the lowest: compound 2; then compounds 1 and 3 (each within the scatter of the next).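

In this assay, going by these compounds alone, 2-fluoro-4-methoxyphenyl in place of 4-fluoro-3-methoxyphenyl gives the first sized step on a double-bonded chain carbon bound to a double-bonded chain carbon (a 2.0-fold higher number from compound 1 to compound 3 (0.30 log units; within the scatter)). With the same atoms joined differently, this change does not separate the two compounds beyond the scatter. No available evidence bears on the reason for this result. On these data alone, whether a different group at this place, such as an amine or a carboxylic acid, would give a step beyond the scatter remains open.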